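Methoxy Added to the Phenyl Ring of Compound 3

The source may hold more compounds than are shown below. What is called first, only, known or untested is meant among the compounds shown, and "the series" means these compounds.

Compound 3, `Clc1ccc(/C=N/Nc2nc(-c3ccccc3)cs2)c(Cl)c1`, was tested in a functional assay, read by spectrophotometry, with a stated time of 15 min, tested at 60 ug/mL (a lower number here means a weaker effect, a higher number a stronger effect of the compound at the concentration tested), and compound 3 gave 92.8%. Among the three measured compounds this places compound 3 second highest. The nearest number belongs to compound 2, `Fc1ccc(-c2csc(N/N=C/c3cccs3)n2)cc1`, which in this assay gave 94.6%, a difference that lies within the scatter of the measurement. The furthest number belongs to compound 1, `COC(=O)c1cc(-c2csc(N/N=C/c3ccc(Cl)cc3Cl)n2)ccc1OCc1ccccc1`, which in this assay gave 41.9%, a gap beyond the scatter. Going by the values given here, no pair of measured compounds differs in only one place, so no single-change step is known from these numbers.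

Compound 4, `COc1ccc(-c2csc(N/N=C/c3ccc(Cl)cc3Cl)n2)cc1`, differs from compound 3 by one change: methoxy in place of hydrogen on an aromatic carbon. From the compounds shown here alone, compound 1 carries a more elaborate substituted phenyl ring and a much lower value, but that comparison involves several changes at once, and the effect of a methoxy alone is untested here. Compound 4 is therefore expected to remain close to compound 3, with a step of a number 7.8 percentage points lower from compound 3 to compound 4 (within the scatter) in this assay not beyond the scatter. Compound 4 is estimated at 85%, with a range from 60% to 97%.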

Compound 4, a percentage reported as inhibition, at one concentration (the size of the read-out at that concentration, not a potency): 86.9%
Beside the measured number, compound 4's estimate is 1.9 percentage points below it; low and high end bracket the measured number.
By their numbers in this assay, from the lowest: compound 1; then compounds 4, 3 and 2 (each within the scatter of the next).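

In this assay, methoxy in place of hydrogen gives a number 5.9 percentage points lower from compound 3 to compound 4 (within the scatter), the first single-change step among these compounds. On this aromatic carbon, para to a large group, the read-out therefore does not separate methoxy from hydrogen, so the change from phenyl to 4-methoxyphenyl leaves no effect that can be told from the scatter at the concentration tested. No supporting measurement is available to explain this outcome.

The compounds shown leave open whether this tolerance extends beyond methoxy to a different group at the same place, such as an amine, a carboxylic acid or a longer alkoxy chain. Going by these compounds alone, they also leave open how methoxy would read at another carbon of this ring, since this single step covers only one group at one place.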